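Piperazine aryl variation in the aminothiophene ketone series

The source may hold more compounds than are shown below. What is called first, only, known or untested is meant among the compounds shown, and "the series" means these compounds.

Measured so far:
compound 1, `Nc1scc(CN2CCN(c3cccc(Cl)c3Cl)CC2)c1C(=O)c1ccc(Cl)cc1`, 3.2%
compound 2, `Nc1scc(CN2CCN(c3ccc(Cl)cc3F)CC2)c1C(=O)c1ccc(Cl)cc1`, -9.4%
compound 3, `Nc1scc(CN2CCN(c3cccc(F)c3)CC2)c1C(=O)c1ccc(Cl)cc1`, -37%

In a functional assay on CHO cells with adenosine receptor A1 (Homo sapiens) as the target, read by cAMP accumulation and immunoassay, with a stated time of 6 min, tested at 0.1 uM (a higher number here means a weaker effect of the compound at the concentration tested, a lower number a stronger effect), compound 3 stands lowest of the three numbers. The nearest is compound 2, with the step of a number 27.6 percentage points lower from compound 2 to compound 3 (beyond the scatter), the furthest compound 1, with the step of a number 40.2 percentage points lower from compound 1 to compound 3 (beyond the scatter); both steps lie beyond the scatter. The remaining pair, a number 12.6 percentage points lower from compound 1 to compound 2 (beyond the scatter), is a modest step in the same direction.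

Compound 4, `Nc1scc(CN2CCN(c3cccc(F)c3F)CC2)c1C(=O)c1ccc(Cl)cc1`, is not yet measured. It differs from compound 3 in one place: fluoro in place of hydrogen on an aromatic carbon. Read one bond further out, the change is 3-fluorophenyl to 2,3-difluorophenyl.

Among the measured compounds shown here, the steps that bear on it are those leading to compound 3: both the dichloro pattern of compound 1 and the chloro-fluoro pattern of compound 2 gave higher numbers than the single fluoro group of compound 3. Returning to a two-halogen pattern is therefore expected to move the number upward in this assay, though the entering group is smaller than the chloro groups of compound 1 and compound 2, so a step smaller than a number 40.2 percentage points lower from compound 1 to compound 3 (beyond the scatter) reversed is expected. For compound 4 the estimated step is a number 20 percentage points higher from compound 3 to compound 4 (beyond the scatter). Compound 4 is estimated at -17%, with a range from -42% to 8%.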

Compound 4, a percentage reported as activity, at one concentration (the size of the read-out at that concentration, not a potency): -5.2%
For compound 4 the middle estimate is 11.8 percentage points below the measured one; the range from low to high includes it.
By their numbers in this assay, from the lowest: compound 3; then compounds 2, 4 and 1 (each within the scatter of the next, the first and the last beyond it).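

In this assay, among the compounds shown here, one fluoro group entering ortho to a fluoro group is enough to give a number 31.8 percentage points higher from compound 3 to compound 4 (beyond the scatter), the first step in the set that changes a single atom, so this aromatic carbon is clearly not indifferent to substitution and even the smallest halogen registers there. With this fluoro group in place, the two-fluoro pattern cannot be separated from either chloro-bearing pattern, with a number 4.2 percentage points higher from compound 2 to compound 4 (within the scatter) and a number 8.4 percentage points lower from compound 1 to compound 4 (within the scatter), although the step between compound 1 and compound 2 lies beyond the scatter, so the halogen pattern as a whole is not without effect. For the compounds shown here, nothing measured on these compounds speaks to why a single fluoro group at this place moves the number so far.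

Open, from the compounds shown here alone, is whether the shift belongs to the entering fluoro group alone or depends on the 3-fluoro group already present, a question that 2-fluorophenyl and unsubstituted phenyl would settle. Also open, going by these compounds, is whether a methyl or methoxy group on this same aromatic carbon would read like fluoro, which would show whether the effect is tied to a halogen at all.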